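A nitrobenzyl swap with one reading behind it

The source may hold more compounds than are shown below. What is called first, only, known or untested is meant among the compounds shown, and "the series" means these compounds.

Compounds tested in an ADME assay on J774.A1 cells (Mus musculus) for cytotoxicity, read by MTT assay, with a stated time of 48 h (on this read-out lower numbers stand for higher toxicity in this test and higher numbers for lower toxicity in this test), and their results
compound 1 `Cc1ccc(-n2cc(COC(=O)c3c(C)nc4ccccc4c3-c3ccccc3)nn2)cc1` gives 39000 nM
compound 2 `Cc1nc2ccccc2c(-c2ccccc2)c1C(=O)OCc1cn(-c2ccc(F)cc2)nn1` gives "not determined" (no result reported)
compound 3 `Cc1nc2ccc(Cl)cc2c(-c2ccccc2)c1C(=O)OCc1cn(-c2ccc(F)cc2)nn1` gives "not determined" (no result reported)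

Compound 3 has no place on the numerical scale. Its entry holds no single number, and the same is true of compound 2, so compound 1 alone provides a reading. Compound 4 `Cc1nc2ccc(Cl)cc2c(-c2ccccc2)c1C(=O)OCc1cn(Cc2ccc([N+](=O)[O-])cc2)nn1` differs from compound 3 in one place, with 4-nitrobenzyl in place of 4-fluorophenyl on an aromatic nitrogen. For the measured compounds named here, no measured step shows what a change of this kind does in this assay and compound 3 offers no starting value. Going by the values given here, the only reference is compound 1 at (39000 nM), and that is thin support. The expectation is therefore of no shift beyond the usual scatter from that reading, in either direction. For compound 4 the estimate is an expected 35000 nM within a range of 12000 nM to 100000 nM on this read-out.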

Compound 4, half-maximal cytotoxic concentration: 75000 nM
Estimate against measurement, compound 4: 2.1-fold (0.33 log units) below, within the range that was stated.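

For the compounds shown here, compound 3 carries no single number in this assay, so no step to compound 4 can be read. No evidence on hand bears on the reading of compound 4. From the compounds shown here alone, what 4-nitrobenzyl in place of 4-fluorophenyl does to this read-out stays open.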